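The compounds below may be only part of what the source reports. "The series", "measured", "known", "first", "only" and "open" are said of these compounds alone.

Compound 1 `Nc1nc(N)nc(-c2cc(F)ccc2Cl)n1` is the reference point of this small series; in a functional assay on the whole organism with Rattus norvegicus as the target, at a dose of 20 mg/kg by the intraperitoneal route (a higher number here means more inhibition at the dose given (going by the name of the read-out), a lower number less inhibition), compound 1 gives 78%. Compound 3 `Nc1nc(N)nc(-c2cc(F)ccc2Br)n1` gives 78%, level with compound 1 at the digits reported, the two together the highest of the three numbers. Compound 2 `Nc1nc(N)nc(-c2cccc(F)c2)n1` gives 70%, a step of a number 8 percentage points lower from compound 1 to compound 2 (within the scatter). The next compound, compound 4 `Nc1nc(N)nc(-c2ccccc2Cl)n1`, differs from compound 1 by hydrogen in place of fluoro on an aromatic carbon. Among the compounds with values here, no measured step removes a fluoro; the nearest comparisons are the loss of a halogen, a number 8 percentage points lower from compound 1 to compound 2 (within the scatter), and the halogen exchange, no change at the digits printed from compound 1 to compound 3 (within the scatter), both inside the scatter, as is a number 8 percentage points higher from compound 2 to compound 3 (within the scatter). For compound 4 the expected step is therefore a number 4 percentage points lower from compound 1 to compound 4 (within the scatter), nothing beyond the scatter. Compound 4 is estimated at 74%, with a range of 55% to 88%.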

Compound 4, a percentage reported as inhibition, in the whole organism at one dose (the size of the read-out at that dose, not a potency): 36%
For compound 4 the middle estimate is 38 percentage points above the measured one; the whole stated range lies above it.
By their numbers in this assay, from the lowest: compound 4; then compounds 2, 1 and 3 (each within the scatter of the next).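

In this assay, within the data shown here, hydrogen in place of fluoro gives a number 42 percentage points lower from compound 1 to compound 4 (beyond the scatter) and is the only step that lies beyond the scatter. The steps at the chloro place, its loss and its exchange for bromo, both kept the fluoro and stayed within the scatter, so the carbon para to the chloro group is the first place shown to respond to a change. No measurement here accounts for this loss.

Going by these compounds, whether the response needs fluoro itself or any group other than hydrogen on this carbon remains open. A methyl, a methoxy or an amine at this place would separate the two.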